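This account rests on a few compounds, and the source may have more. Where it says the series, first, only, none or still open, it means among the compounds named here.

Values measured so far in a functional assay on the whole organism with Rattus norvegicus as the target; a lower number here means that less compound is needed, a higher number that more compound is needed for the effect:
Compound 1 (`CCOc1ccccc1-c1ncc(-c2nn[nH]n2)c(O)n1`): 0.09 mg/kg
Compound 2 (`CCCOc1ccccc1-c1ncc(-c2nn[nH]n2)c(O)n1`): 0.04 mg/kg
Compound 3 (`CC(C)COc1ccccc1-c1ncc(-c2nn[nH]n2)c(O)n1`): 0.1 mg/kg

Compound 2 holds the lowest of these three numbers, and its steps to both of the others lie beyond the scatter. Compound 4 (`CCC(C)Oc1ccccc1-c1ncc(-c2nn[nH]n2)c(O)n1`) keeps the shared core and turns the propoxy of compound 2 into sec-butoxy. The change, (methyl in place of hydrogen on a saturated chain carbon bound to an oxygen on an aromatic ring and a saturated chain carbon), is a methyl in place of hydrogen on a saturated chain carbon bound to an oxygen on an aromatic ring and a saturated chain carbon.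

Among the compounds with values here, no measured compound carries a methyl at that place, so the evidence is indirect. A methyl in place of hydrogen two bonds along the chain from an oxygen on an aromatic ring gave a 2.3-fold lower number from compound 1 to compound 2 (0.35 log units; beyond the scatter). A methyl in place of hydrogen on a saturated chain carbon bound to two saturated chain carbons gave a 2.5-fold higher number from compound 2 to compound 3 (0.40 log units; beyond the scatter). The second is the closer parallel, as it also branches the propyl chain, and it goes against the lower number seen with the first. A modest rise in the number is therefore expected, no larger than that second step. The expected change is a 2.0-fold higher number from compound 2 to compound 4 (0.30 log units; within the scatter), which leaves compound 4 near compound 1 and compound 3. For compound 4 the estimate is 0.08 mg/kg, with an expected range from 0.03 mg/kg to 0.2 mg/kg.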

Compound 4, dose for 50% inhibition: 0.05 mg/kg
Compound 4: the middle estimate sits 1.6-fold (0.20 log units) above what was measured; low and high end bracket the measured number.
By their numbers in this assay, from the lowest: compounds 2, 4, 1 and 3 (each within the scatter of the next, the first and the last beyond it).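

In this assay, a methyl on the saturated chain carbon bound to an oxygen on an aromatic ring and a saturated chain carbon gives a 1.3-fold higher number from compound 2 to compound 4 (0.10 log units; within the scatter) at this position, while a methyl on the saturated chain carbon bound to two saturated chain carbons had given a 2.5-fold higher number from compound 2 to compound 3 (0.40 log units; beyond the scatter) on the same propyl chain, so the place of the branch matters to how the step reads. The sec-butyl of compound 4 also cannot be told apart from the isobutyl or the ethyl on the oxygen, with a 2.0-fold lower number from compound 3 to compound 4 (0.30 log units; within the scatter) and a 1.8-fold lower number from compound 1 to compound 4 (0.26 log units; within the scatter) as the steps, even though the propyl of compound 2 stands beyond the scatter from both of those groups. Nothing in the available evidence accounts for the difference between the two methyl places.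

The compounds shown leave open whether a longer chain such as butyl or pentyl, or a ring such as cyclopentyl, on the oxygen would fall in this same narrow band. They also leave open what an ethyl, a second methyl, a hydroxyl or an amine would do on the chain carbon that carries the new methyl.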